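A few compounds are considered here, and "the series" means these few. Any claim that something is new, unique, unknown or untested is made for them only; others in the source may bear on it.

Measured so far in an assay on isolated protein for inhibition of coagulation factor X (Oryctolagus cuniculus), tested at 1 uM; on this read-out higher numbers stand for more inhibition at the one concentration tested (going by the name of the read-out) and lower numbers for less inhibition:
compound 1 `O=C1[C@@H](NS(=O)(=O)c2cc3ccc(Cl)nc3s2)CCN1Cc1cc2[nH]cccc-2n1`, 23%
compound 2 `O=C1[C@@H](NS(=O)(=O)c2cc3ncccc3s2)CCN1Cc1cc2c[nH]ccc-2n1`, 61%
compound 3 `O=C1[C@@H](NS(=O)(=O)c2cc3c(Cl)nccc3s2)CCN1Cc1cc2c[nH]ccc-2n1`, 35%

Compound 3 stands second highest of the three numbers: compound 2 lies above it by a number 26 percentage points lower from compound 2 to compound 3 (beyond the scatter), and compound 1 lies below it, beyond the scatter.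

Compound 4 `O=C1[C@@H](NS(=O)(=O)c2cc3ccc(Cl)nc3s2)CCN1Cc1cc2c[nH]ccc-2n1` is yet to be measured in this assay. Its change from compound 3 is a group of 10 heavy atoms (7 carbon, 1 nitrogen, 1 sulfur, 1 chlorine; one five-membered aromatic ring with 1 hetero atom, one six-membered aromatic ring with 1 hetero atom) in place of a group of 10 heavy atoms (7 carbon, 1 nitrogen, 1 sulfur, 1 chlorine; one five-membered aromatic ring with 1 hetero atom, one six-membered aromatic ring with 1 hetero atom), on a sulfonyl sulfur. Within the data shown here, the same atoms are present in both, only joined differently, so the one measured step, a number 26 percentage points lower from compound 2 to compound 3 (beyond the scatter), which adds a chlorine rather than moving it, bears only loosely on this rearrangement. Among the measured compounds shown here, the group on the sulfonyl sulfur of compound 4 is also the one carried on a differently joined core by compound 1, which gives 23%; no step between compound 1 and compound 4 is known, so this is a weak pointer only.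

For the measured compounds named here, with no direct precedent for the rearrangement, compound 4 is expected to stay near compound 3, with a wide range; the expected step is a number 3 percentage points lower from compound 3 to compound 4 (within the scatter), estimated as 32% (between 14% and 52%).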

Compound 4, a percentage reported as inhibition, at one concentration (the size of the read-out at that concentration, not a potency): 51%
Compound 4: middle estimate off by 19 percentage points, on the low side; low and high end bracket the measured number.
By their numbers in this assay, from the lowest: compound 1; then compound 3; then compounds 4 and 2 (each within the scatter of the next).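

In this assay the placement of the chlorine within the group on the sulfonyl sulfur counts, not only its presence: the rearrangement gives a number 16 percentage points higher from compound 3 to compound 4 (beyond the scatter) and shows that these two isomeric groups are not interchangeable. Chlorine on this group is also not always penalised, since a number 26 percentage points lower from compound 2 to compound 3 (beyond the scatter) contrasts with a number 10 percentage points lower from compound 2 to compound 4 (within the scatter) for the arrangement in compound 4. With the sulfonyl group held constant, the other end of the molecule also responds, as the rearranged group on the saturated chain carbon bound to an amide-type nitrogen in a ring gives a number 28 percentage points higher from compound 1 to compound 4 (beyond the scatter) in this series.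

Nothing available here explains these differences. Open, on these data alone, is whether methyl, methoxy or an amine in place of the chlorine of compound 4 would retain its inhibition.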